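The source may hold more compounds than are shown below. What is called first, only, known or untested is meant among the compounds shown, and "the series" means these compounds.

Measured in a functional assay on DU-145 cells (Homo sapiens) for inhibition, read by trypan blue exclusion, with a stated time of 96 h; on this read-out lower numbers stand for stronger inhibition of growth and higher numbers for weaker inhibition of growth:
- Compound 1 `O=C(/C(=C\c1c[nH]c2ccc(Cl)cc12)SCc1ccc(F)cc1)c1ccc(Br)cc1`: 1000 nM
- Compound 2 `COc1ccc(/C=C(/SCc2ccc(F)cc2)C(=O)c2ccc(Br)cc2)cc1`: 50000 nM
- Compound 3 `COc1ccc(S/C(=C/c2ccc(Br)cc2)C(=O)c2ccc(Br)cc2)cc1`: 20000 nM

Compound 3, at 20000 nM, stands in the middle of the three numbers. Compound 2 reads higher at 50000 nM, and compound 1 reads lower at 1000 nM.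

Compound 4 `O=C(/C(=C\c1ccc(Br)cc1)SCc1ccc(F)cc1)c1ccc(Br)cc1` has not yet been measured. It differs from compound 3 in one place, with 4-fluorobenzyl in place of 4-methoxyphenyl on a sulfur. Within the data shown here, no measured step changes this sulfur group, so the size of the change cannot be read directly. Among the measured compounds shown here, the one measured step, a 50-fold higher number from compound 1 to compound 2 (1.70 log units; beyond the scatter), is large, but it lies elsewhere, with 4-methoxyphenyl in place of 5-chloro-1H-indol-3-yl on a double-bonded chain carbon. Compound 4 lacks the 5-chloro-1H-indol-3-yl group, as compound 3 does. Compound 2 carries the 4-fluorobenzyl group without it and still reads 50000 nM, so the incoming group gives no reason to expect a low number. No change beyond the scatter is therefore expected in this assay, and the expected step is a 1.3-fold lower number from compound 3 to compound 4 (0.12 log units; within the scatter). The estimate for compound 4 is 15000 nM, with an expected range from 4000 nM to 50000 nM.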

Compound 4, concentration for 50% growth inhibition: 25000 nM
Compound 4: the middle estimate sits 1.7-fold (0.22 log units) below what was measured, and the stated range covers the measured number.
By their numbers in this assay, from the lowest: compound 1; then compounds 3, 4 and 2 (each within the scatter of the next, the first and the last beyond it).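

In this assay the change on the sulfur, 4-fluorobenzyl in place of 4-methoxyphenyl, comes to a 1.3-fold higher number from compound 3 to compound 4 (0.10 log units; within the scatter) and stays within the usual scatter, so this first direct reading of the position does not tell the two groups apart when 4-bromophenyl stands on the double-bonded chain carbon. With 4-fluorobenzyl kept on the sulfur, bromo in place of methoxy on an aromatic carbon gives a 2.0-fold lower number from compound 2 to compound 4 (0.30 log units; within the scatter) and also stays within the scatter, while 4-bromophenyl in place of 5-chloro-1H-indol-3-yl gives a 25-fold higher number from compound 1 to compound 4 (1.40 log units; beyond the scatter) and is a large step beyond it. The large difference among these compounds now appears with two separate replacements of the 5-chloro-1H-indol-3-yl group of compound 1, and no step on the sulfur matches it.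

Going by these compounds, whether an amine or a carboxylic acid on a longer chain would read the same on the sulfur stays open, as does whether 4-methoxyphenyl and 4-fluorobenzyl still read alike there when the 5-chloro-1H-indol-3-yl group is present. No independent evidence is available on why the two sulfur groups read alike.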